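This account rests on a few compounds, and the source may have more. Where it says the series, first, only, none or still open, it means among the compounds named here.

In a physicochemical assay for lipophilicity, read by mass spectrometry (a higher number here means a more lipophilic compound, a lower number a more polar compound), compound 1 `COc1cc2c(cc1OC)C(=O)C(C(=O)Nc1ccccc1)C2` gives 2.2, compound 2 `COc1cc2c(cc1OC)C(=O)C(C(=O)Nc1ccccc1C)C2` gives 2.69 and compound 3 `COc1ccccc1NC(=O)C1Cc2cc(OC)c(OC)cc2C1=O` gives 2.08. Methoxy in place of hydrogen gave a number 0.12 log units lower from compound 1 to compound 3 (within the scatter), and methoxy in place of methyl gave a number 0.61 log units lower from compound 2 to compound 3 (beyond the scatter). Compound 3 therefore cannot be told apart from compound 1 and stands clearly under compound 2. Compound 4 `CCOc1ccccc1NC(=O)C1Cc2cc(OC)c(OC)cc2C1=O` differs from compound 3 as follows: methyl in place of hydrogen on a saturated chain carbon bound to an oxygen on an aromatic ring. This is methyl in place of hydrogen on a saturated chain carbon bound to an oxygen on an aromatic ring, or methoxy to ethoxy. For the measured compounds named here, the nearest precedent is methyl in place of hydrogen on an aromatic carbon, which gave a number 0.49 log units higher from compound 1 to compound 2 (beyond the scatter). It sits at a different place, so a modest rise of similar or somewhat smaller size is expected. The estimated step is a number 0.37 log units higher from compound 3 to compound 4 (beyond the scatter). For compound 4 the expected value is 2.45, with an estimated range of 2.15 to 2.8.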

Compound 4, partition coefficient: 2.42
For compound 4 the middle estimate is 0.03 log units above the measured one; the measured number falls inside the stated range.
By their numbers in this assay, from the lowest: compounds 3, 1, 4 and 2 (each within the scatter of the next, the first and the last beyond it).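

Methyl in place of hydrogen on a saturated chain carbon bound to an oxygen on an aromatic ring gave a number 0.34 log units higher from compound 3 to compound 4 (beyond the scatter) in this assay, so this place also responds to a single added methyl. Ethoxy in place of hydrogen gave a number 0.22 log units higher from compound 1 to compound 4 (within the scatter), and ethoxy in place of methyl gave a number 0.27 log units lower from compound 2 to compound 4 (within the scatter). Ethoxy thus cannot be told apart from either hydrogen or methyl, whereas methoxy stood clearly under methyl. Nothing at hand explains the rise. From the compounds shown here alone, whether a longer chain such as propoxy, or a chain ending in an amine, would extend or reverse this step stays open.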